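The compounds below may be only part of what the source reports. "The series", "measured", "known", "first", "only" and "open" are said of these compounds alone.

Measured so far in an ADME assay on MT4 cells (Homo sapiens) for cytotoxicity, read by MTT assay, with a stated time of 5 days; a lower number here means that less compound is tolerated, a higher number that more compound is tolerated:
- compound 1 `Cc1cc(OCC(=O)Nc2cccc(Cl)c2)nc(Nc2ccc(C#N)cc2)n1`: 32200 nM
- compound 2 `Cc1cnc(Nc2ccc(C#N)cc2)nc1OCC(=O)Nc1ccccc1F`: > 331000 nM

Compound 2 gives > 331000 nM, which is a limit of the assay and not a number. It therefore stands at the limit of > 331000 nM in this assay, at which 1 of the 2 values shown sits. Within the data shown here, compound 1 is the only one of the pair with a numerical reading in this assay.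

Compound 3 `Cc1cnc(Nc2ccc(C#N)cc2)nc1OCC(=O)Nc1ccc(Br)cc1` carries 4-bromophenyl in place of 2-fluorophenyl on an amide-type nitrogen.

Among the measured compounds shown here, the only number is that of compound 1, 32200 nM, so a measurable value is expected for the next compound, with less tolerated than for compound 2. The expected change is an at least 5.5-fold lower number from compound 2 to compound 3 (0.74 log units; beyond the scatter), a downward step beyond the usual scatter, and its size is uncertain as it starts from a limit. For compound 3 the estimated value is 60000 nM, with an expected range of 15000 nM to 280000 nM.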

Compound 3, half-maximal cytotoxic concentration: 34700 nM
Compound 3: middle estimate off by 1.7-fold (0.24 log units), on the high side; low and high end bracket the measured number.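

In this assay, among these compounds, the exchange of 2-fluorophenyl for 4-bromophenyl on the amide-type nitrogen provides the first comparison between compounds that differ in one place, and this position proves sensitive: an at least 9.5-fold lower number from compound 2 to compound 3 (0.97 log units; beyond the scatter). Compound 2 gives > 331000 nM, which is a limit of the assay and not a number. The true size of the step therefore remains unknown, and only its lower bound can be read: the limit of > 331000 nM in this assay, at which 1 of the 3 values shown sits.

As far as these compounds go, the change replaces fluorine with bromine and also moves the halogen from the 2-position to the 4-position, so the contribution of each remains open. A 4-fluorophenyl or 2-bromophenyl group on the same nitrogen would separate the two, while an unsubstituted phenyl group would show how either halogen compares with none.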